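Ring Nitrogen Entering the Arylpiperazine of Compound 2

The source may hold more compounds than are shown below. What is called first, only, known or untested is meant among the compounds shown, and "the series" means these compounds.

Going by the values given here, compound 2 `Cc1ccccc1N1CCN(CCCNc2ncccc2C(=O)N(C)C)CC1` stands lowest of the two numbers so far in a functional assay for antagonist activity at Alpha-1A adrenergic receptor (Oryctolagus cuniculus) (on this read-out lower numbers stand for tighter binding and higher numbers for weaker binding), giving 2 nM. Its nearest neighbour is compound 1 `CN(C)C(=O)c1cccnc1NCCCN1CCN(c2ccccc2)CC1`, which in this assay gives 6.31 nM; the step of a 3.2-fold lower number from compound 1 to compound 2 (0.50 log units; beyond the scatter) came with a methyl in place of hydrogen on an aromatic carbon. Compound 3 `Cc1cnccc1N1CCN(CCCNc2ncccc2C(=O)N(C)C)CC1` keeps that methyl and differs from compound 2 only in the change (3-methylpyridin-4-yl in place of 2-methylphenyl on an amine nitrogen in a ring). Among the compounds with values here, no measured step exchanges a ring carbon for a ring nitrogen, so the one step that was measured does not bear directly on this change; it only shows that the shared core tolerates modest variation on that ring. Without a precedent, compound 3 is expected to show a modest step of a 3.0-fold higher number from compound 2 to compound 3 (0.48 log units; beyond the scatter) toward a higher number. The estimate for compound 3 in this assay is 6 nM, with a range from 1.5 nM to 25 nM.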

Compound 3, dissociation constant: 200 nM
Estimate against measurement, compound 3: 33-fold (1.52 log units) below; the measured number lies above the stated range.
By their numbers in this assay, from the lowest: compound 2; then compound 1; then compound 3.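

In this assay, the exchange at this amine nitrogen in a ring proves far from neutral: 3-methylpyridin-4-yl in place of 2-methylphenyl gives a 100-fold higher number from compound 2 to compound 3 (2.00 log units; beyond the scatter), although both groups have the same heavy-atom count and neither carries a net charge. The methyl does not preserve the earlier gain once the ring holds nitrogen, for 3-methylpyridin-4-yl in place of phenyl still gives a 32-fold higher number from compound 1 to compound 3 (1.50 log units; beyond the scatter), which places the methylated pyridine ring behind even the unsubstituted phenyl ring. Nothing available explains this large loss.

The compounds shown leave open whether the step belongs to the ring nitrogen alone or to its pairing with the methyl. As far as these compounds go, how an unmethylated pyridin-4-yl or a pyrimidin-2-yl group would stand on the same amine nitrogen also remains open.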